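A few compounds are considered here, and "the series" means these few. Any claim that something is new, unique, unknown or untested is made for them only; others in the source may bear on it.

Working notes on the methylbenzyl series. In an ADME assay on MT4 cells (Homo sapiens) for cytotoxicity, read by MTT assay, with a stated time of 4 days (a lower number here means that less compound is tolerated, a higher number that more compound is tolerated), compound 1 `Cc1ccc(OCCn2ccc(=O)n(Cc3ccccc3)c2=O)cc1` gives 187000 nM. Compound 2 `Cc1ccc(OCCn2ccc(=O)n(Cc3ccccc3C)c2=O)cc1` gives 46000 nM, and the change of methyl in place of hydrogen on an aromatic carbon reads as a 4.1-fold lower number from compound 1 to compound 2 (0.61 log units; beyond the scatter). Compound 3 `Cc1ccc(OCCn2ccc(=O)n(Cc3cccc(C)c3)c2=O)cc1` stands at >= 38000 nM, which is a limit and not a number. Neither a step that the limit leaves unreadable from compound 1 to compound 3 nor a step that the limit leaves unreadable from compound 2 to compound 3 gives a size.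

Compound 4 `Cc1ccc(Cn2c(=O)ccn(CCOc3ccc(C)cc3)c2=O)cc1` has the same atoms as compound 3, joined differently: 4-methylphenyl in place of 3-methylphenyl on a saturated chain carbon bound to an aromatic nitrogen. In words, this is 4-methylphenyl in place of 3-methylphenyl on a saturated chain carbon bound to an aromatic nitrogen.

Going by the values given here, no measured step covers this exact change, and the only readable step in this assay is the one that adds the methyl, not one that relocates it. Compound 2, which also carries that added methyl, gives 46000 nM, so compound 4 is expected to fall in the same region and not to return to the level of compound 1. No shift beyond the scatter is expected, in either direction, and the expected step is a step that the limit leaves unreadable from compound 3 to compound 4. For compound 4 the estimated value is 55000 nM, with an expected range of 25000 nM to 150000 nM.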

Compound 4, half-maximal cytotoxic concentration: 250000 nM
For compound 4 the middle estimate is 4.5-fold (0.66 log units) below the measured one, outside the stated range (above it).
By their numbers in this assay, from the lowest: compound 2; then compounds 1 and 4 (each within the scatter of the next).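

In this assay, the change from the 2-methylbenzyl group to the 4-methylbenzyl group gives a 5.4-fold higher number from compound 2 to compound 4 (0.74 log units; beyond the scatter), so among these compounds the reading depends on where the methyl stands and not only on its presence. Adding a methyl is therefore not enough to lower the number: the change to the 4-methylbenzyl group gives a 1.3-fold higher number from compound 1 to compound 4 (0.13 log units; within the scatter), which leaves compound 1 and compound 4 level, and only compound 2 stands apart from them. Compound 3 carries a limit and not a number, so every step that involves compound 3 cannot be read: the limit of >= 38000 nM in this assay, at which 1 of the 4 values shown sits.

From the compounds shown here alone, whether 3-methylbenzyl reads with 2-methylbenzyl or with 4-methylbenzyl remains open, and so the three placings of the methyl cannot yet be set in a full order. Also open, going by these compounds, is how this assay reads when a group other than methyl, such as an amine, a carboxylic acid or a longer chain, stands in the methyl's place on 4-methylbenzyl.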